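A few compounds are considered here, and "the series" means these few. Any claim that something is new, unique, unknown or untested is made for them only; others in the source may bear on it.

In a functional assay on SK-MEL-28 cells (Homo sapiens) for antiproliferative activity, read by sulforhodamine B assay, with a stated time of 48 h (on this read-out lower numbers stand for stronger inhibition and higher numbers for weaker inhibition), compound 1 (`C/C=C(\C)C(=O)O[C@H]1C=CC(=O)O[C@H]1CCC(=O)[C@H](C)O`) gives 24000 nM and compound 2 (`C/C=C(\C)C(=O)O[C@H]1C=CC(=O)O[C@H]1COC(=O)[C@H](C)O`) gives 13000 nM, so compound 2 stands level with compound 1 within the scatter. Compound 3 (`C/C=C(\C)C(=O)O[C@H]1C=CC(=O)O[C@H]1CNC(=O)[C@H](C)O`) keeps the shared core and differs from compound 2 by ((1-hydroxyethyl)carbonyl)amino in place of ((1-hydroxyethyl)carbonyl)oxy on a saturated chain carbon bound to a saturated ring carbon. Among the measured compounds shown here, the only measured step that bears on this change is a 1.8-fold lower number from compound 1 to compound 2 (0.27 log units; within the scatter), made at the same place and within the scatter. The expected step, a 1.4-fold higher number from compound 2 to compound 3 (0.14 log units; within the scatter), therefore stays within the scatter, with no firm direction. Compound 3 is estimated at 18000 nM, with an expected range of 8000 nM to 40000 nM.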

Compound 3, half-maximal inhibitory concentration: 28000 nM
Compound 3: the middle estimate sits 1.6-fold (0.19 log units) below what was measured; measured number inside the range.
By their numbers in this assay, from the lowest: compounds 2, 1 and 3 (each within the scatter of the next, the first and the last beyond it).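

In this assay, among the compounds shown here, the change to ((1-hydroxyethyl)carbonyl)amino from ((1-hydroxyethyl)carbonyl)oxy on a saturated chain carbon bound to a saturated ring carbon gives a 2.2-fold higher number from compound 2 to compound 3 (0.33 log units; beyond the scatter) and so is the first change at this place to pass the scatter, though only modestly. The change from ((1-hydroxyethyl)carbonyl)methyl gives a 1.2-fold higher number from compound 1 to compound 3 (0.07 log units; within the scatter) and leaves that pair level, so only the oxy and amino forms stand apart. No measurement shown accounts for this difference. As far as these compounds go, it remains open whether a longer chain in place of the 1-hydroxyethyl part, or an amine in place of its hydroxyl, would change the number more.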